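The compounds below may be only part of what the source reports. "The series", "measured", "known", "first", "only" and "open" are said of these compounds alone.

Measured so far in a functional assay on the whole organism (Tail, strain ICR) with Mus musculus as the target, in the tail flick test, with a stated time of 120 min, at a dose of 25 umol/kg by the oral route; on this read-out lower numbers stand for a weaker effect and higher numbers for a stronger effect at the one dose given:
- compound 1, `N=C(N)NCCC[C@H](NC(=O)CN(c1nc(Cl)nc2[nH]cnc12)C1CC1)C(=O)OCc1ccccc1`: 10.2%
- compound 2, `O=C(CN(c1nc(Cl)nc2[nH]cnc12)C1CC1)N[C@@H](CC(=O)OCc1ccccc1)C(=O)OCc1ccccc1`: 12.1%

Compound 2 and compound 1 share one core and differ only in the group on a saturated chain carbon, two bonds along the chain from an amide-type nitrogen and a carbonyl carbon. The step between them, a number 1.9 percentage points higher from compound 1 to compound 2 (within the scatter), is within the scatter, so the two numbers cannot be set apart, and compound 2 stands at one end of a pair that behaves as a single level rather than as a ranking.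

Compound 3, `NC(=O)CC[C@H](NC(=O)CN(c1nc(Cl)nc2[nH]cnc12)C1CC1)C(=O)OCc1ccccc1`, is not yet measured. It differs from compound 2 at the same place: carbamoylmethyl in place of benzyloxycarbonyl on a saturated chain carbon, two bonds along the chain from an amide-type nitrogen and a carbonyl carbon. Going by the values given here, the only measured step that bears on this is the one from compound 1 to compound 2, which swapped a group at this very position and produced a change within the scatter. Among the compounds with values here, with that as the sole guide, the exchange of benzyloxycarbonyl for carbamoylmethyl is expected to give no step beyond the scatter in this assay, in either direction.

The estimate for compound 3 is therefore 11%, with a range from 3% to 22%, and the expected step of a number 1.1 percentage points lower from compound 2 to compound 3 (within the scatter).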

Compound 3, a percentage reported as activity, at one dose (the size of the read-out at that dose, not a potency): 36%
The estimate for compound 3 lay 25 percentage points below the measured number; measured number outside the range, above it.
By their numbers in this assay, from the lowest: compounds 1 and 2 (each within the scatter of the next); then compound 3.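

In this assay, going by these compounds alone, this position turns out not to be flat, as the earlier pair suggested: carbamoylmethyl in place of benzyloxycarbonyl gives a number 23.9 percentage points higher from compound 2 to compound 3 (beyond the scatter), the first change here to clear the scatter. The comparison with the other neighbour points the same way, with the swap at the end of the side chain, on a saturated chain carbon, three bonds along the chain from an amide-type nitrogen and a carbonyl carbon, giving a number 25.8 percentage points higher from compound 1 to compound 3 (beyond the scatter), so compound 3 stands apart from two compounds that cannot be told from each other, even though the groups those two carry differ widely. Nothing measured here explains why the 2-carbamoylethyl side chain stands out from the other two.

On these data alone, with only these side chains, it remains open whether the carbamoyl end itself matters or the chain length matters as well, and what a carboxylic acid, an amine or a longer chain would give at this position. Since each compound is read at one dose and one time point in a whole animal, the numbers also leave open how compound 3 would behave at other doses or times.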